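From Dimethoxyphenyl to Hydroxyphenyl on a Shared Core

The source may hold more compounds than are shown below. What is called first, only, known or untested is meant among the compounds shown, and "the series" means these compounds.

Compound 1 `COc1ccc(Nc2nc(N[C@H]3CC[C@H](N)CC3)nc3c2ncn3CCC(C)C)c(OC)c1` gives 5500 nM
Compound 2 `CCCCn1cnc2c(Nc3cccc(Cl)c3)nc(N[C@H]3CC[C@H](N)CC3)nc21` gives 2000 nM

In a functional assay on K562 cells (Homo sapiens) for inhibition, read by fluorescence, with a stated time of 72 h (on this read-out lower numbers stand for stronger inhibition of growth and higher numbers for weaker inhibition of growth), compound 1 has the higher of the two numbers, and the gap to compound 2 lies beyond the usual scatter. Compound 3 `CC(C)CCn1cnc2c(Nc3cccc(O)c3)nc(N[C@H]3CC[C@H](N)CC3)nc21` has not yet been measured. It carries 3-hydroxyphenyl in place of 2,4-dimethoxyphenyl on a nitrogen on an aromatic ring, a difference counted as 3-hydroxyphenyl in place of 2,4-dimethoxyphenyl on a nitrogen on an aromatic ring in full. Going by the values given here, no measured pair isolates this change, so the expectation is tentative. The estimated step is a 3.7-fold lower number from compound 1 to compound 3 (0.56 log units; beyond the scatter) and it is expected to run toward stronger inhibition of growth. For compound 3 the expected value is 1500 nM with an estimated range of 400 nM to 5000 nM overall.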

Compound 3, concentration for 50% growth inhibition: 7600 nM
Estimate against measurement, compound 3: 5.1-fold (0.70 log units) below; the measured number lies above the stated range.
By their numbers in this assay, from the lowest: compound 2; then compounds 1 and 3 (each within the scatter of the next).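

In this assay, going by these compounds alone, the first step that isolates this position is a 1.4-fold higher number from compound 1 to compound 3 (0.14 log units; within the scatter), with 3-hydroxyphenyl in place of 2,4-dimethoxyphenyl on a nitrogen on an aromatic ring. Two groups that differ in their counts of heavy atoms, hydrogen-bond donors and hydrogen-bond acceptors therefore give numbers that cannot be told apart on the shared core. No measurement at hand explains this result.

On these data alone, whether a phenyl ring carrying an amine or a carboxylic acid on that nitrogen would give a different number remains open. Compound 2 differs from compound 3 in more than one place, so it cannot show how a chlorine-bearing ring compares at this position.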